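Swapping a urea for an amide on the shared core

A few compounds are considered here, and "the series" means these few. Any claim that something is new, unique, unknown or untested is made for them only; others in the source may bear on it.

Among the compounds with values here, compound 2 `O=C(Nc1ccc(-n2cc(-c3ccncc3)c(-c3ccc(Cl)c(O)c3)n2)cc1)Nc1ccc(Cl)c(C(F)(F)F)c1` is tested in a functional assay on SK-MEL-28 cells (Homo sapiens) for antiproliferative activity, read by sulforhodamine B assay, with a stated time of 48 h (on this read-out lower numbers stand for stronger inhibition and higher numbers for weaker inhibition), where compound 2 gives 1630 nM, the lowest of the two numbers known so far. Within the data shown here, the only other measured compound, compound 1 `COc1cc(-c2nn(-c3ccc(NC(=O)c4ccc(Cl)c(Cl)c4)cc3)cc2-c2ccncc2)ccc1Cl`, carries a different outer ring and gives 40300 nM. Compound 3 `O=C(Nc1ccc(-n2cc(-c3ccncc3)c(-c3ccc(Cl)c(O)c3)n2)cc1)c1ccc(Cl)c(Cl)c1` has not yet been measured; it keeps the core of compound 2 but has 3,4-dichlorophenyl in place of (4-chloro-3-(trifluoromethyl)phenyl)amino on a carbonyl carbon. No direct comparison tells how this change acts, so a moderate loss is expected from compound 2 to compound 3, a 3.7-fold higher number from compound 2 to compound 3 (0.57 log units; beyond the scatter). Compound 3 is estimated at 6000 nM, with a range from 1500 nM to 25000 nM.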

Compound 3, half-maximal inhibitory concentration: 2940 nM
The estimate for compound 3 lay 2.0-fold (0.31 log units) above the measured number; low and high end bracket the measured number.
By their numbers in this assay, from the lowest: compounds 2 and 3 (each within the scatter of the next); then compound 1.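

In this assay, 3,4-dichlorophenyl in place of (4-chloro-3-(trifluoromethyl)phenyl)amino on a carbonyl carbon shows no clear change (a 1.8-fold higher number from compound 2 to compound 3 (0.26 log units; within the scatter)), so this position tolerates both groups in this pair. By contrast, hydrogen in place of methyl on an oxygen on an aromatic ring has a large effect (a 14-fold lower number from compound 1 to compound 3 (1.14 log units; beyond the scatter)), which shows that this second site matters in this pair. No measurement available here explains either result. From the compounds shown here alone, it remains open whether an amine or a longer chain on that carbonyl carbon would fit as well, and whether an ethyl group on that oxygen would behave like methyl.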